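The source may report more compounds than this note shows. Statements on the series, on what has been measured and on what is new or still open speak of the compounds shown alone.

Three compounds have been measured in a physicochemical assay for lipophilicity, read by HPLC, at pH 7.5; a higher number here means a more lipophilic compound, a lower number a more polar compound:

Compound 1, `CC[C@@H](Nc1c(C#N)c(-c2ccc(-c3cccc(C)c3F)cc2)nc2cnccc12)C(N)=O`: in this assay compound 1 gives 3.
Compound 2, `CCOc1ccccc1-c1ccc(-c2nc3cnccc3c(N[C@H](CC)C(N)=O)c2C#N)cc1`: in this assay compound 2 gives 3.
Compound 3, `CCOc1ccccc1-c1ccc(-c2nc3cnccc3c(N[C@H](CC)C(=O)O)c2C#N)cc1`: in this assay compound 3 gives 2.1.

Compound 4, `CC[C@@H](Nc1c(C#N)c(-c2ccc(-c3cccc(C)c3F)cc2)nc2cnccc12)C(=O)O`, has not yet been measured. It differs from compound 3 in one place: 2-fluoro-3-methylphenyl in place of 2-ethoxyphenyl on an aromatic carbon. The same change has already been made once among the measured compounds, from compound 2 to compound 1: 2-fluoro-3-methylphenyl in place of 2-ethoxyphenyl on an aromatic carbon. There it made no change at the digits printed from compound 2 to compound 1 (within the scatter). The two pairs do not share a core. Compound 2 and compound 3 differ by hydroxy in place of amino on a carbonyl carbon, and that step gave a number 0.90 log units lower from compound 2 to compound 3 (beyond the scatter). The place of the change is the same in both pairs, so it counts as the same change made on a different core.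

Since the change gave no change at the digits printed from compound 2 to compound 1 (within the scatter), the step from compound 3 to compound 4 is expected to be about no change at the digits printed from compound 3 to compound 4 (within the scatter). Compound 4 is therefore estimated to give around 2.1, somewhere between 1.7 and 2.5.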

Compound 4, distribution coefficient: 2.1
For compound 4 middle estimate and measured number coincide at the digits printed; low and high end bracket the measured number.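

In this assay, putting 2-fluoro-3-methylphenyl in place of 2-ethoxyphenyl gave no change at the digits printed from compound 3 to compound 4 (within the scatter) and, on the other core, no change at the digits printed from compound 2 to compound 1 (within the scatter) so the change carried across the two cores shown without moving the number. Hydroxy in place of amino on a carbonyl carbon gave a number 0.90 log units lower from compound 1 to compound 4 (beyond the scatter) and, with 2-ethoxyphenyl in place, a number 0.90 log units lower from compound 2 to compound 3 (beyond the scatter) so that step also read the same on both sides. These are only two pairs, which shows agreement between these two cores and not a rule for any other core, and nothing shown explains the result.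

The only groups shown on the carbonyl carbon are amino and hydroxy, so a methyl ester there remains an open case. On these data alone, it is also open whether a phenyl ring carrying an amine or a longer chain would leave the number as unchanged as 2-fluoro-3-methylphenyl did.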